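A few compounds are considered here, and "the series" means these few. Any claim that something is new, unique, unknown or untested is made for them only; others in the source may bear on it.

Compound 1, `C=CCc1ccc(OC(=O)c2cccc(F)c2)c(OC)c1`: 2.7 in a physicochemical assay for lipophilicity; on this read-out lower numbers stand for lower lipophilicity and higher numbers for higher lipophilicity
Compound 2, `C=CCc1ccc(OC(=O)c2ccccn2)c(OC)c1`: 0.86 in this assay
Compound 3, `C=CCc1ccc(OC(=O)c2ccc(C)cc2)c(OC)c1`: 2.87 in this assay

Compound 3 gives the highest of the three numbers in this assay. Its nearest neighbour is compound 1, since a number 0.17 log units higher from compound 1 to compound 3 (within the scatter); its furthest is compound 2, since a number 2.01 log units higher from compound 2 to compound 3 (beyond the scatter). The one large effect among the measured steps belongs to the pyridin-2-yl group, seen in a number 1.84 log units lower from compound 1 to compound 2 (beyond the scatter) and again in a number 2.01 log units higher from compound 2 to compound 3 (beyond the scatter).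

Compound 4, `C=CCc1ccc(OC(=O)c2ccccc2C)c(OC)c1`, is not yet measured. It differs from compound 3 in one place: 2-methylphenyl in place of 4-methylphenyl on a carbonyl carbon. For the measured compounds named here, no measured step moves a methyl group from one position of a phenyl ring to another, so none bears directly on this change. Going by the values given here, the only step that keeps a phenyl ring at the carbonyl carbon, a number 0.17 log units higher from compound 1 to compound 3 (within the scatter), is small, and the two structures here hold the same atoms. The step of a number 0.07 log units lower from compound 3 to compound 4 (within the scatter) is therefore expected to stay within the scatter, with no clear direction. Compound 4 is estimated at 2.8, between 2.5 and 3.1.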

Compound 4, partition coefficient: 2.87
For compound 4 the middle estimate is 0.07 log units below the measured one; the measured number falls inside the stated range.
By their numbers in this assay, from the lowest: compound 2; then compounds 1, 3 and 4 (each within the scatter of the next).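

The methyl group's place on the phenyl ring makes no measurable difference here: 2-methylphenyl in place of 4-methylphenyl on a carbonyl carbon gives no change at the digits printed from compound 3 to compound 4 (within the scatter) in this assay. For the compounds shown here, the new compound also reproduces the large gap to the pyridin-2-yl ester, with a number 2.01 log units higher from compound 2 to compound 4 (beyond the scatter) on that side, and with a number 0.17 log units higher from compound 1 to compound 4 (within the scatter) it stays level with the 3-fluorophenyl ester, so pyridin-2-yl remains the only group at this carbon that stands apart among the four compounds. Nothing available accounts for the methyl move leaving the number unchanged.

Going by these compounds, it remains open whether a phenyl ring carrying an amine or a carboxylic acid would stay with compound 1, compound 3 and compound 4 or fall towards compound 2. Whether a longer chain in place of the methyl would behave like the methyl is also unknown.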